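The compounds below may be only part of what the source reports. "The series", "measured", "known", "first", "only" and "open" are said of these compounds alone.

Three compounds measured in a functional assay on NCI-H460 cells (Homo sapiens) for inhibition, read by sulforhodamine B assay, with a stated time of 48 h (a lower number here means a stronger inhibitor of growth, a higher number a weaker inhibitor of growth), share two nitro-bearing phenyl groups but differ in their central ring. Compound 1 `N#CCC1=NN=C(c2ccc([N+](=O)[O-])cc2)C(CC(=O)c2ccc([N+](=O)[O-])cc2)O1` gives 2600 nM. Compound 2 `N#CCC1=C(C#N)CC(c2ccc([N+](=O)[O-])cc2)=C(CC(=O)c2ccc([N+](=O)[O-])cc2)O1` gives 80 nM, and compound 3 `N#CCC1=C(C#N)CC(c2ccc([N+](=O)[O-])cc2)=C(CC(=O)c2ccc(Br)cc2)O1` gives 3600 nM. The difference between the core of compound 1 and the core of compound 2 is not broken down here.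

Compound 2 and compound 3 differ in one place: bromo in place of nitro on an aromatic carbon. This change produced a 45-fold higher number from compound 2 to compound 3 (1.65 log units; beyond the scatter).

The unmeasured compound 4 `N#CCC1=NN=C(c2ccc([N+](=O)[O-])cc2)C(CC(=O)c2ccc(Br)cc2)O1` relates to compound 1 in the same way: bromo in place of nitro on an aromatic carbon. The place of the change is described in the same words for both pairs, so this is the same kind of change, made on a different core.

For the measured compounds named here, whether the second core responds as the first did is unknown, as only one example of the change exists. Because compound 1 already gives 2600 nM, a step of similar direction would push compound 4 to a markedly higher number. A weaker response than a 45-fold higher number from compound 2 to compound 3 (1.65 log units; beyond the scatter) is also plausible, since the cores differ. The expected step is a 15-fold higher number from compound 1 to compound 4 (1.19 log units; beyond the scatter), and compound 4 is estimated at 40000 nM, with a likely range from 8000 nM to 200000 nM.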

Compound 4, concentration for 50% growth inhibition: 40000 nM
The estimate for compound 4 equals the measured number at the digits printed, and the stated range covers the measured number.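

On the core of compound 1, putting a 4-bromophenyl in place of the 4-nitrophenyl in this assay gives a 15-fold higher number from compound 1 to compound 4 (1.19 log units; beyond the scatter), so this change weakens growth inhibition on both cores shown. For the compounds shown here, the direction carries over from one core to the other, but the size does not, as comparing the two steps shows: the same change on two cores in this assay, a 45-fold higher number (1.65 log units; beyond the scatter) from compound 2 to compound 3 and a 15-fold higher number (1.19 log units; beyond the scatter) from compound 1 to compound 4, 2.9-fold (0.47 log units) apart, beyond the scatter of two such steps With only two cores, this does not show that the direction would hold on a third core, and it does not explain why the two steps differ in size, so the step seen on one core gives only a rough guide to the step on another.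

The compounds shown compare only nitro and bromo at this place, leaving open how an amine, a carboxylic acid or a methoxy group there would behave on either core. They also leave open what would happen if the same change were made on the other 4-nitrophenyl group, which stays in place in all four compounds.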